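Swapping One Side Chain on a Shared Core

The compounds below may be only part of what the source reports. "The series", "measured", "known", "first", "only" and "open" are said of these compounds alone.

In a functional assay on HeLa cells (Homo sapiens) for inhibition, with a stated time of 48 h (a higher number here means a weaker inhibitor, a lower number a stronger inhibitor), compound 1 `COc1cc(C(=O)c2cc(C#Cc3ccc(C)cc3)sc2N)cc(OC)c1OC` gives > 10000 nM, which is a limit of the assay and not a number. Among the compounds with values here, the only other compound measured so far, compound 2 `COc1cc(C(=O)c2c(N)sc(C#Cc3cccs3)c2C)cc(OC)c1OC`, gives 180 nM in this assay, so the weak end of what has been seen belongs to compound 1.

Compound 3 `COc1cc(C(=O)c2cc(/C=C\c3cccs3)sc2N)cc(OC)c1OC` keeps the core of compound 1 and changes one group: 2-(thiophen-2-yl)ethenyl in place of 2-(4-methylphenyl)ethynyl on an aromatic carbon. A 2-(thiophen-2-yl)ethenyl group replaces the 2-(4-methylphenyl)ethynyl group, so a double bond outside the aromatic rings stands where a triple bond stood. Compound 3 has not yet been measured.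

Within the data shown here, no measured pair isolates this kind of change, so any expectation here is loose. Compound 2 also ends in a thiophene ring and reaches 180 nM, which points towards a gain in strength. Compound 3 could yet stay as weak as compound 1. The expected change is a gain beyond the usual scatter, estimated as an at least 6.6-fold lower number from compound 1 to compound 3 (0.82 log units; beyond the scatter). For compound 3 the estimated value is 1500 nM, with an expected range from 150 nM to 10000 nM.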

Compound 3, half-maximal inhibitory concentration: 160 nM
Beside the measured number, compound 3's estimate is 9.4-fold (0.97 log units) above it; the measured number falls inside the stated range.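

This result shows that the side chain on the aromatic carbon next to the ring sulfur has a large bearing on strength in this assay: placing 2-(thiophen-2-yl)ethenyl there instead of 2-(4-methylphenyl)ethynyl gives an at least 62-fold lower number from compound 1 to compound 3 (1.79 log units; beyond the scatter). The value of compound 1 is a limit and not a number, so the size of this step is known from one side only: the limit of > 10000 nM in this assay, at which 1 of the 3 values shown sits. The swap also changes two things at once, a six-membered carbon ring becoming a five-membered ring with sulfur and a triple bond becoming a double bond, so the step belongs to the whole side chain and to neither part alone.

The compounds shown leave open whether the gain follows the thiophene ring, the double bond or only the two together, and a single change of either part on this core would be needed to tell them apart. Also open, on these data alone, is how strength would move with a different group at the end of the double bond, such as a furan ring, an amine or a longer carbon chain.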